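A few compounds are considered here, and "the series" means these few. Any claim that something is new, unique, unknown or untested is made for them only; others in the source may bear on it.

Measured in a physicochemical assay for lipophilicity, at pH 7.4; on this read-out lower numbers stand for lower lipophilicity and higher numbers for higher lipophilicity:
compound 1 `COc1ccc2c(c1)C=CN(C)C(=O)[C@@H]2C` gives 4.3
compound 2 `C[C@H]1C(=O)N(C)C=Cc2cc(CCO)ccc21` gives 2.6

Compound 2 at 2.6 holds the lower of the two numbers. The change to compound 3 `CCS(=O)(=O)c1ccc2c(c1)C=CN(C)C(=O)[C@@H]2C` is ethylsulfonyl in place of 2-hydroxyethyl on an aromatic carbon, counted as ethylsulfonyl in place of 2-hydroxyethyl on an aromatic carbon and still unmeasured. Going by the values given here, the one measured step bearing on this is a number 1.70 log units lower from compound 1 to compound 2 (beyond the scatter) and it is large, but no measured compound carries ethylsulfonyl. Compound 3 has no methoxy, like compound 2 at 2.6 so only a small upward step, possibly within the scatter, is expected in this assay for this change. The estimated move is a number 0.20 log units higher from compound 2 to compound 3 (within the scatter) and no larger one is expected. For compound 3 the estimate is 2.8 with an expected range from 2.2 to 3.4.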

Compound 3, distribution coefficient: 3.1
Compound 3: the middle estimate sits 0.30 log units below what was measured; measured number inside the range.
By their numbers in this assay, from the lowest: compound 2; then compound 3; then compound 1.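

In this assay ethylsulfonyl in place of methoxy on this aromatic carbon gives a number 1.20 log units lower from compound 1 to compound 3 (beyond the scatter) so the fall is not particular to 2-hydroxyethyl. The two replacements do not land at the same level, with a number 0.50 log units higher from compound 2 to compound 3 (beyond the scatter) so how far the number falls at this position depends on the group that enters. Nothing available explains that gap. The compounds shown leave open whether an amine or a carboxylic acid on this aromatic carbon would bring the number below that of compound 2. They also leave open how a longer chain ending in hydroxy would compare with 2-hydroxyethyl.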